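Triazole substituent exchange: hexyl to cyclopropyl, cytotoxicity notes

The source may hold more compounds than are shown below. What is called first, only, known or untested is meant among the compounds shown, and "the series" means these compounds.

Among the compounds with values here, compound 1 `CCCCCCc1cn(C(c2ccccc2)c2cc3cc(Br)ccc3nc2OC)nn1` gives 7.17% in an ADME assay on SK-OV-3 cells (Homo sapiens) for cytotoxicity, read by sulforhodamine B assay, with a stated time of 48 h, tested at 10 uM (on this read-out lower numbers stand for less inhibition and higher numbers for more inhibition at the one concentration tested (going by the name of the read-out)), and stands second highest of the three numbers known. Compound 3 `CCCCCCCCc1cn(C(c2ccccc2)c2cc3cc(Br)ccc3nc2OC)nn1` gives 2.06% and compound 2 `COc1nc2ccc(Br)cc2cc1C(c1ccccc1)n1cc(-c2ccccc2)nn1` gives 13.7%; the steps of a number 5.1 percentage points lower from compound 1 to compound 3 (within the scatter) and a number 6.5 percentage points higher from compound 1 to compound 2 (within the scatter) lie within the scatter, while a number 11.6 percentage points lower from compound 2 to compound 3 (beyond the scatter) lies beyond it. Compound 4 `COc1nc2ccc(Br)cc2cc1C(c1ccccc1)n1cc(C2CC2)nn1` differs from compound 1 by cyclopropyl in place of hexyl on an aromatic carbon. Within the data shown here, the steps that bear on this change are a number 5.1 percentage points lower from compound 1 to compound 3 (within the scatter) and a number 6.5 percentage points higher from compound 1 to compound 2 (within the scatter), both small, so no step beyond the scatter is expected in this assay for compound 4. Compound 4 is therefore estimated at 8%, with a range from 0% to 20%. The step of a number 0.8 percentage points higher from compound 1 to compound 4 (within the scatter) that this estimate means is expected to remain within the scatter.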

Compound 4, a percentage reported as inhibition, at one concentration (the size of the read-out at that concentration, not a potency): 3.52%
Compound 4: the middle estimate sits 4.5 percentage points above what was measured; measured number inside the range.
By their numbers in this assay, from the lowest: compounds 3, 4, 1 and 2 (each within the scatter of the next, the first and the last beyond it).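

In this assay, cyclopropyl on this aromatic carbon cannot be told apart from either alkyl chain: a number 3.7 percentage points lower from compound 1 to compound 4 (within the scatter) and a number 1.5 percentage points higher from compound 3 to compound 4 (within the scatter). Phenyl now separates from a second substituent, a number 10.2 percentage points lower from compound 2 to compound 4 (beyond the scatter), although compound 1 goes against this pattern, as its step to compound 2 stays within the scatter. No accompanying measurement offers an explanation for these steps. As far as these compounds go, whether an amine or a carboxylic acid at this aromatic carbon would move the number beyond the scatter remains open, as does whether a substituted phenyl would stay apart from cyclopropyl and octyl.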